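Extending the Octyl Chain on Compound 2 to Compound 4

The source may report more compounds than this note shows. Statements on the series, on what has been measured and on what is new or still open speak of the compounds shown alone.

Values measured in a functional assay on SiHa cells (Homo sapiens) for cytotoxicity, read by MTT assay, with a stated time of 48 h; a lower number here means a stronger inhibitor, a higher number a weaker inhibitor:
compound 1, `CCCCCCCCNC(=O)[C@@H](NC(=O)c1cc2ccccc2o1)[C@@H](C)O`: 66500 nM
compound 2, `CCCCCCCCNC(=O)[C@@H](NC(=O)c1nccc2ccccc12)[C@@H](C)O`: 66000 nM
compound 3, `CCCCCCCCCCCCNC(=O)[C@@H](NC(=O)c1cc2ccccc2o1)[C@@H](C)O`: 12900 nM

Compound 2 gives the second highest of the three numbers in this assay; its value and that of compound 1 lie within the scatter of each other, whereas compound 3 shows a lower number, beyond the scatter. Compound 4, `CCCCCCCCCCCCCCNC(=O)[C@@H](NC(=O)c1nccc2ccccc12)[C@@H](C)O`, has not yet been measured. It differs from compound 2 by hexyl in place of hydrogen on a saturated chain carbon, eight bonds along the chain from an amide-type nitrogen. Among the measured compounds shown here, one measured step bears on this change: a 5.2-fold lower number from compound 1 to compound 3 (0.71 log units; beyond the scatter), in which the same place on the chain received a shorter extension on the core of compound 1. For the measured compounds named here, the change into compound 4 is of the same kind but adds a longer chain, so a downward step at least as large as that one is expected in this assay, with the caveat that only one precedent exists and the two cores differ. Compound 4 is therefore expected to give about 8000 nM in this assay, within a range from 3000 nM to 25000 nM. The step this estimate implies is an 8.3-fold lower number from compound 2 to compound 4 (0.92 log units; beyond the scatter).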

Compound 4, half-maximal inhibitory concentration: 21600 nM
Compound 4: middle estimate off by 2.7-fold (0.43 log units), on the low side, and the stated range covers the measured number.
By their numbers in this assay, from the lowest: compounds 3 and 4 (each within the scatter of the next); then compounds 2 and 1 (each within the scatter of the next).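

In this assay, lengthening the chain lowers the number on the core of compound 2 as well, so the downward step seen so far on the core of compound 1 is not confined to that core: hexyl in place of hydrogen gives a 3.1-fold lower number from compound 2 to compound 4 (0.49 log units; beyond the scatter). The larger addition did not bring a larger step, since butyl on the core of compound 1 gave a 5.2-fold lower number from compound 1 to compound 3 (0.71 log units; beyond the scatter), although the two steps stand on different cores and cannot show how the number depends on chain length. Nothing available explains this step or the difference between the two steps.

The compounds shown leave open whether butyl and hexyl would give different steps on one shared core. They also leave open how a still longer chain, or an amine at the end of the chain, would read in this assay.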